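Hydroxy for methylsulfanyl on the fused core

A few compounds are considered here, and "the series" means these few. Any claim that something is new, unique, unknown or untested is made for them only; others in the source may bear on it.

Working notes on the series around compound 1 `CCc1nc(C)c2cnnc(SC)n12`. In a functional assay for inhibition, with Homo sapiens as the target (on this read-out lower numbers stand for stronger inhibition and higher numbers for weaker inhibition), compound 1 gives > 48000 nM, which is a limit of the assay and not a number. Compound 2 `CCCc1nc(C)c2cnnc(SC)n12` carries methyl in place of hydrogen on a saturated chain carbon, two bonds along the chain from an aromatic carbon, and in this assay compound 2 gives > 48000 nM, likewise a limit. The step that the two limits leave unreadable from compound 1 to compound 2 therefore cannot be read, and the limit of > 48000 nM in this assay, at which 2 of the 2 values shown sit, is all the two values carry. Compound 1 thus stands at the limit, with no number of its own.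

Compound 3 `CCc1nc(C)c2cnnc(O)n12` differs from compound 1 by hydroxy in place of methylsulfanyl on an aromatic carbon. Among the compounds with values here, no measured step touches this aromatic carbon, and the only recorded step, on the chain, is itself unreadable, so nothing here sizes the change. The expectation for compound 3 in this assay rests solely on the limits seen for compound 1 and compound 2, and is that it will again be reported as a limit. The estimate for compound 3 is 60000 nM, with a range from 20000 nM to 200000 nM. This estimated position corresponds to the step that the limit leaves unreadable from compound 1 to compound 3, expected to be nothing beyond the scatter.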

Compound 3, half-maximal inhibitory concentration: > 48000 nM
Compound 3 was reported as a limit; the forecaster's own chance of this, stated with the estimate: 85%; the middle value lies beyond the limit too.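

In this assay compound 3 gives > 48000 nM, a limit of the assay and not a number. Within the data shown here, the change from compound 1 to compound 3 therefore yields no step that can be read. The values shown share one position: the limit of > 48000 nM in this assay, at which 3 of the 3 values shown sit. The compounds shown leave open which change on the shared core, if any, would give a measurable value.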